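The compounds below may be only part of what the source reports. "The series", "measured", "known", "first", "only" and "open" are said of these compounds alone.

Measured in an ADME assay on NIH3T3 cells (Mus musculus) for cytotoxicity, read by MTT assay, with a stated time of 24 h; a lower number here means a stronger inhibitor, a higher number a weaker inhibitor:

- Compound 1 `O=C(CSc1nnc(-c2ccncc2)o1)N/N=C/c1ccc(F)cc1`: 170000 nM
- Compound 2 `O=C(CSc1nnc(-c2ccncc2)o1)N/N=C/c1ccc(Br)cc1`: 169000 nM
- Compound 3 `O=C(CSc1nnc(-c2ccncc2)o1)N/N=C/c1ccc(O)cc1`: 158000 nM

Compound 3 does not stand apart from the other two compounds. Its value of 158000 nM lies within the scatter of both, as a 1.1-fold lower number from compound 1 to compound 3 (0.03 log units; within the scatter) and a 1.1-fold lower number from compound 2 to compound 3 (0.03 log units; within the scatter) show.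

The next compound is compound 4 `O=C(CSc1nnc(-c2ccncc2)o1)N/N=C/c1cccc(F)c1`, which has 3-fluorophenyl in place of 4-hydroxyphenyl on a carbon with a double bond to nitrogen.

Among the measured compounds shown here, three measured steps bear on this change. The closest is a 1.1-fold lower number from compound 1 to compound 3 (0.03 log units; within the scatter), where hydroxy replaces fluoro. The others, a 1.0-fold lower number from compound 1 to compound 2 (0.00 log units; within the scatter) and a 1.1-fold lower number from compound 2 to compound 3 (0.03 log units; within the scatter), also change only the group on the aromatic ring, and all three stay within the scatter. For the measured compounds named here, no measured compound carries the 3-fluorophenyl group, so that part of the change remains untested.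

No change beyond the scatter is therefore expected in this assay, and the estimated step is a 1.0-fold higher number from compound 3 to compound 4 (0.02 log units; within the scatter). Compound 4 is expected at 165000 nM, with an estimated range of 100000 nM to 270000 nM.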

Compound 4, half-maximal inhibitory concentration: 205000 nM
Compound 4: middle estimate off by 1.2-fold (0.09 log units), on the low side; measured number inside the range.
By their numbers in this assay, from the lowest: compounds 3, 2, 1 and 4 (each within the scatter of the next).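

In this assay, among the compounds shown here, the earlier compounds varied only which group sat at the 4-position of the phenyl ring, whereas compound 4 also shows that 3-fluorophenyl in place of 4-fluorophenyl leaves the result within the scatter (a 1.2-fold higher number from compound 1 to compound 4 (0.08 log units; within the scatter)). The same holds when 3-fluorophenyl replaces 4-bromophenyl (a 1.2-fold higher number from compound 2 to compound 4 (0.08 log units; within the scatter)) or 4-hydroxyphenyl (a 1.3-fold higher number from compound 3 to compound 4 (0.11 log units; within the scatter)), so removing the hydroxy group's hydrogen-bond donor and acceptor shows no change beyond the scatter either. Nothing available here explains this flat result.

As far as these compounds go, all four compounds share one core and carry a single halogen or hydroxy group on the phenyl ring, so the effect of an amine, a carboxylic acid or a longer alkyl chain there remains open. Also open, from the compounds shown here alone, is whether changing the shared core would move the number beyond the scatter.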